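The source may report more compounds than this note shows. Statements on the series, on what has been measured and on what is new or still open speak of the compounds shown alone.

Three compounds sharing one core have numbers in an ADME assay on GES1 cells (Homo sapiens) for inhibition, read by MTT assay, with a stated time of 72 h; on this read-out lower numbers stand for stronger inhibition and higher numbers for weaker inhibition: compound 1 `Cc1cc(Nc2cc(-c3ccccc3)[nH]n2)n2nc(SCc3ccc(Br)cc3)nc2n1` gives 39300 nM, compound 2 `Cc1cc(Nc2cc(-c3ccccc3)[nH]n2)n2nc(SCc3ccc(Cl)cc3)nc2n1` gives 31800 nM, and compound 3 `C#CCSc1nc2nc(C)cc(Nc3cc(-c4ccccc4)[nH]n3)n2n1` gives 45700 nM. Compound 3 therefore stands level with the other two, within the scatter of both. Still unmeasured is compound 4 `Cc1cc(Nc2cc(-c3ccccc3)[nH]n2)n2nc(SCc3cccc4ccccc34)nc2n1`, which differs from compound 3 as follows: naphthalen-1-yl in place of ethynyl on a saturated chain carbon bound to a sulfur. In words, naphthalen-1-yl sits in place of ethynyl on a saturated chain carbon bound to a sulfur.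

Two measured steps make a change at this same place: a 1.2-fold higher number from compound 1 to compound 3 (0.07 log units; within the scatter) and a 1.4-fold higher number from compound 2 to compound 3 (0.16 log units; within the scatter). Both trade an aromatic group for ethynyl, and neither moves the number beyond the scatter. The swap of chloro for bromo, a 1.2-fold lower number from compound 1 to compound 2 (0.09 log units; within the scatter), is equally small. For the measured compounds named here, no measured compound carries naphthalen-1-yl, so this extrapolation remains uncertain. The expected change is a 1.4-fold lower number from compound 3 to compound 4 (0.15 log units; within the scatter), which means no shift beyond the scatter is anticipated. Compound 4 is estimated to give 32000 nM, within an expected range of 14000 nM to 65000 nM.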

Compound 4, half-maximal inhibitory concentration: 36300 nM
Compound 4: the middle estimate sits 1.1-fold (0.05 log units) below what was measured; the measured number falls inside the stated range.
By their numbers in this assay, from the lowest: compounds 2, 4, 1 and 3 (each within the scatter of the next).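

Naphthalen-1-yl, with its two six-membered aromatic rings of carbon only, extends what this position has shown: on a saturated chain carbon bound to a sulfur, it moves nothing beyond the scatter in this assay. Against the earlier groups, the steps are a 1.3-fold lower number from compound 3 to compound 4 (0.10 log units; within the scatter), a 1.1-fold higher number from compound 2 to compound 4 (0.06 log units; within the scatter) and a 1.1-fold lower number from compound 1 to compound 4 (0.03 log units; within the scatter), so all four compounds read alike here, with no compound going against that. Nothing available explains this sameness.

Going by these compounds, whether a group carrying an amine or a carboxylic acid on this same chain carbon would shift the number remains open, since every group here has only carbon or a halogen-bearing aromatic ring. The compounds also leave open whether replacing the phenyl or the methyl on the shared core would change the number.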